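The source may hold more compounds than are shown below. What is called first, only, known or untested is meant among the compounds shown, and "the series" means these compounds.

In this assay, a functional assay on Sf9 cells for antagonist activity at histamine H2 receptor (Homo sapiens), read by scintillation counting and GTPgammaS binding, with a stated time of 90 min (a lower number here means a less potent compound, a higher number a more potent compound, by a factor of ten per unit of this negative logarithm), compound 2 `CN/C(=N/C#N)NCCCCc1nc(N)n[nH]1` reaches only a limit of detection rather than a number: compound 2 gives < 5. Compound 1 `Cc1nccn1CCCCCN/C(=N\C#N)NCCSc1ccccc1` likewise ends at a limit in this assay, and compound 1 gives < 5. So both values shown so far sit at the limit of < 5 in this assay, at which 2 of the 2 values shown sit, which leaves compound 2 with no measured position above it and no measured neighbour from which a step could be read. Compound 3 `N#C/N=C(\NCCCCc1nc(N)n[nH]1)NCCSc1ccccc1` has not yet been measured; it differs from compound 2 by (phenylsulfanyl)methyl in place of hydrogen on a saturated chain carbon bound to an amine nitrogen. Among the compounds with values here, as no step between measured compounds is known, only a guess of the size is possible: the change is expected to move potency by a number at least 0.20 log units higher from compound 2 to compound 3 (that floor lies within the scatter) in this assay, a modest rise, with a fair chance that only a limit is reported again. Compound 3 is therefore estimated at 5.2 in this assay, within a range of 4.5 to 6.2.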

Compound 3, negative logarithm of the antagonist equilibrium constant: < 5
Compound 3: only a limit was reported; the forecaster's own chance of this, stated with the estimate: 50%; at least 0.20 log units between middle value and limit.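

Compound 3 also ends at a limit, so the steps to it from compound 2 and from compound 1 cannot be read: the limit of < 5 in this assay, at which 3 of the 3 values shown sit.

The compounds shown leave open whether (phenylsulfanyl)methyl in place of hydrogen changes potency at all, and how far compound 1, compound 2 and compound 3 lie from that limit.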